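Swapping the chain end of an indole myeloperoxidase inhibitor

The source may hold more compounds than are shown below. What is called first, only, known or untested is meant among the compounds shown, and "the series" means these compounds.

Of the compounds shown here, three built on one shared core have been tested in an assay on isolated protein for inhibition of Myeloperoxidase (Homo sapiens), read by ELISA, with a stated time of 5 min; on this read-out higher numbers stand for weaker inhibition and lower numbers for stronger inhibition. Compound 1 `NCCCCc1c[nH]c2c(F)cccc12` gives 21 nM. Compound 2 `NCCCc1c[nH]c2ccc(C(=O)O)cc12` is reported as "not active" (no number reported), so no number stands for it. Compound 3 `N#CSCCCc1c[nH]c2ccc(F)cc12` gives 23 nM, and its number and that of compound 1 lie within the usual scatter of each other, so nothing separates the two on this read-out. Compound 4 `CNC(=O)CCCc1c[nH]c2ccc(F)cc12` has not yet been measured in this assay. It differs from compound 3 in one place: methylcarbamoyl in place of cyanosulfanyl on a saturated chain carbon, three bonds along the chain from an aromatic carbon. Going by the values given here, no pair of measured compounds shows this kind of exchange, and the only guide is that compound 2, which also carries a different chain end, gave "not active" (no number reported). The step of an 8.7-fold higher number from compound 3 to compound 4 (0.94 log units; beyond the scatter) is therefore expected to be a weakening beyond the scatter, though a modest one. Compound 4 is estimated at 200 nM, within a range from 40 nM to 2000 nM.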

Compound 4, half-maximal inhibitory concentration: 95 nM
The estimate for compound 4 lay 2.1-fold (0.32 log units) above the measured number; measured number inside the range.
By their numbers in this assay, from the lowest: compounds 1 and 3 (each within the scatter of the next); then compound 4.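

Going by these compounds alone, exchanging cyanosulfanyl for methylcarbamoyl is the first change at this chain end that can be sized on a shared core, and in this assay it gives a 4.1-fold higher number from compound 3 to compound 4 (0.62 log units; beyond the scatter). The step is modest and compound 4 still gives a measured number, so this place accepts a chain end with a carbonyl and an amide hydrogen in place of the nitrile and sulfur, at a limited cost in inhibition. Nothing shown here explains the rise in the number.

Still open, going by these compounds, is how a dimethylcarbamoyl group, which has no amide hydrogen, or a methyl ester would read at this chain end. Also open, on these data alone, is whether the same exchange would cost as much on a longer chain.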